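A few compounds are considered here, and "the series" means these few. Any claim that something is new, unique, unknown or untested is made for them only; others in the source may bear on it.

In a functional assay on cells for antagonist activity at D(4) dopamine receptor (Homo sapiens), read by TR-FRET and cAMP accumulation, with a stated time of 30 min (a lower number here means a stronger inhibitor, a higher number a weaker inhibitor), compound 1 `CCc1cccc(NC(=O)CN2CCN(c3ccccn3)CC2)c1` gives 1310 nM, compound 2 `Cc1ccc(C2CCN(CC(=O)Nc3cccc(C)c3)CC2)cc1` gives 3060 nM, and compound 3 `CCc1cccc(NC(=O)CN2CCN(c3ccc(Cl)cn3)CC2)c1` gives 7060 nM, the highest of the three numbers. Among the compounds with values here, the only single-point step measured so far is a 5.4-fold higher number from compound 1 to compound 3 (0.73 log units; beyond the scatter). Compound 4 `O=C(CN1CCN(c2ccc(Cl)cn2)CC1)Nc1cncnc1` has not yet been measured; it differs from compound 3 in that (pyrimidin-5-yl in place of 3-ethylphenyl on an amide-type nitrogen). Within the data shown here, no measured step touches the group on the amide nitrogen, so nothing here sets the size of this change directly; the only guide is that compound 3 already sits at the weak end of the series. A further loss is expected, and the expected step is a 2.1-fold higher number from compound 3 to compound 4 (0.33 log units; beyond the scatter). Compound 4 is therefore expected to give about 15000 nM, with a range from 4000 nM to 60000 nM.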

Compound 4, half-maximal inhibitory concentration: > 100000 nM
Compound 4: no number, only a limit; the forecaster's own chance of this, stated with the estimate: 35%; middle value at least 6.6-fold (0.82 log units) away from the limit.
By their numbers in this assay, from the lowest: compound 1; then compound 2; then compound 3. At a limit, above all of these: compound 4.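

In this assay, compound 4 reaches only a limit, not a number: the limit of > 100000 nM in this assay, at which 1 of the 4 values shown sits. Putting pyrimidin-5-yl in place of 3-ethylphenyl on the amide-type nitrogen gives an at least 14-fold higher number from compound 3 to compound 4 (1.15 log units; beyond the scatter). Within the data shown here, this is the first measured step at this position, and it shows that the group on the amide nitrogen can decide whether a compound keeps measurable activity here.

The change removes the ethyl group and adds ring nitrogens at once, and the compounds shown do not separate the two. Plain phenyl or pyridin-3-yl on the same nitrogen would help tell them apart.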